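Propargyl Piperidine Alcohols Against Monoamine Oxidase B

The source may hold more compounds than are shown below. What is called first, only, known or untested is meant among the compounds shown, and "the series" means these compounds.

Compound 1 `O=C(Nc1ccccc1)OC1CCCN(Cc2ccccc2)C1`: 33300 nM
Compound 2 `C#CCN1CCC(O)CC1`: > 100000 nM

Of the compounds shown here, two have been measured so far. In an assay on BTI-TN-5B1-4 cells for inhibition of Amine oxidase [flavin-containing] B (Homo sapiens), read by fluorescence and Amplex Red, using microsomes, with a stated time of 15 min (on this read-out higher numbers stand for weaker inhibition and lower numbers for stronger inhibition), compound 1 gives 33300 nM. For compound 2 the result is a limit of the assay and not a number: in this assay compound 2 gives > 100000 nM. On the numbers shown, compound 2 sits at the limit of > 100000 nM in this assay, at which 1 of the 2 values shown sits, so its own position is known only as that limit.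

Compound 3 `C#CCN1CCC(CO)CC1` has not yet been measured. It differs from compound 2 in one place: hydroxymethyl in place of hydroxy on a saturated ring carbon. Going by the values given here, no step between two measured compounds is available, so there is nothing measured that tells how such a change shifts the read-out. Because compound 2 sits at the limit of > 100000 nM in this assay, at which 1 of the 2 values shown sits, the expected step that the limit leaves unreadable from compound 2 to compound 3 is small, none beyond the scatter. Compound 3 is therefore expected to give about 150000 nM in this assay, within a range from 50000 nM to 500000 nM, and the outcome is expected most often to be again only a limit.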

Compound 3, half-maximal inhibitory concentration: > 100000 nM
Compound 3 gave a limit, no number (the forecaster's own chance of this, stated with the estimate: 80%); the middle value lies beyond the limit too.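

Compound 2 and compound 3 each give only a limit in this assay, not a number, so no step can be read for the change from hydroxy to hydroxymethyl: the limit of > 100000 nM in this assay, at which 2 of the 3 values shown sit. The compounds shown leave open whether hydroxymethyl in place of hydroxy on a saturated ring carbon shifts inhibition at all.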